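From Ethyl to Methoxybenzyl on the Ring Nitrogen

The source may report more compounds than this note shows. Statements on the series, on what has been measured and on what is new or still open speak of the compounds shown alone.

Compound 1, `O=C(Nc1ncc(C(=O)O)c2nc(-c3ccco3)nn12)NC1CCCCC1`: > 100000 nM
Compound 2, `CCOC(=O)c1cnc(NCc2ccc(F)cc2)n2nc(-c3ccco3)nc12`: 932 nM
Compound 3, `CCNc1ncc(C(=O)O)c2nc(-c3ccco3)nn12`: 11900 nM

All three were measured in an assay on CHO cells for displacement of a labelled ligand from adenosine receptor A1 (Homo sapiens); a higher number here means a weaker inhibitor, a lower number a stronger inhibitor. For compound 1 the entry is a limit of the assay rather than a number: the limit of > 100000 nM in this assay, at which 1 of the 3 values shown sits. Compound 3 gives 11900 nM, the higher of the two actual numbers. Compound 2 gives 932 nM.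

Going by the values given here, the one single-site step measured, an at least 8.4-fold lower number from compound 1 to compound 3 (0.92 log units; beyond the scatter), swaps a cyclohexylcarbamoyl for an ethyl on the ring nitrogen and says nothing about an aryl group there. Compound 4, `COc1ccc(CNc2ncc(C(=O)O)c3nc(-c4ccco4)nn23)cc1`, differs from compound 3 in 4-methoxyphenyl in place of methyl on a saturated chain carbon bound to a nitrogen on an aromatic ring. Compound 2 carries a benzyl-type group on that same nitrogen but also an ethyl ester in place of the acid, so it differs from compound 3 in two places; its lower number is still the nearest pointer. Compound 4 is therefore expected to come out lower, by a step of a 4.8-fold lower number from compound 3 to compound 4 (0.68 log units; beyond the scatter). The estimate for compound 4 is 2500 nM, expected to fall between 500 nM and 12000 nM.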

Compound 4, inhibition constant: 5760 nM
Compound 4: middle estimate off by 2.3-fold (0.36 log units), on the low side, and the stated range covers the measured number.
By their numbers in this assay, from the lowest: compound 2; then compound 4; then compound 3. At a limit, above all of these: compound 1.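

Going by these compounds alone, compound 4 is the first compound with the carboxylic acid kept that carries an aromatic ring on this nitrogen substituent. In this assay, replacing ethyl with 4-methoxybenzyl gives a 2.1-fold lower number from compound 3 to compound 4 (0.32 log units; beyond the scatter), so in this one pair the added 4-methoxyphenyl on a saturated chain carbon bound to a nitrogen on an aromatic ring brings a modest gain and no loss. Replacing the cyclohexylcarbamoyl gives the larger at least 17-fold lower number from compound 1 to compound 4 (1.23 log units; beyond the scatter), a step whose full size cannot be read because compound 1 stands at a limit of the assay: the limit of > 100000 nM in this assay, at which 1 of the 4 values shown sits.

As far as these compounds go, whether the gain needs the methoxy remains open, since a plain benzyl or a longer chain such as butyl could be set on that nitrogen. Also open, from the compounds shown here alone, is how 4-methoxybenzyl behaves with a primary amide in place of the carboxylic acid.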